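Swapping an aromatic arm for a tert-butyl group

A few compounds are considered here, and "the series" means these few. Any claim that something is new, unique, unknown or untested is made for them only; others in the source may bear on it.

Three measured compounds share a common core and differ in one arm. In a functional assay on CHOK cells for antagonist activity at growth hormone secretagogue receptor type 1 (Homo sapiens), read by calcium flux (on this read-out lower numbers stand for stronger inhibition and higher numbers for weaker inhibition), compound 1 `CCc1nc(N)nc(N)c1-c1ccc(NCc2ccc([N+](=O)[O-])cc2)cc1` gives 23 nM. Compound 2 `CCc1nc(N)nc(N)c1-c1ccc(NCc2ccnc(Cl)c2)cc1` gives 220 nM, and the step of a 9.6-fold higher number from compound 1 to compound 2 (0.98 log units; beyond the scatter). Compound 3 `Nc1nc(N)c(-c2ccc(NCc3ccnc(Cl)c3)cc2)c(COCc2ccccc2)n1` gives 3.6 nM, the lowest of the three numbers, and the step of a 61-fold lower number from compound 2 to compound 3 (1.79 log units; beyond the scatter). Compound 4 `CC(C)(C)CNc1ccc(-c2c(N)nc(N)nc2COCc2ccccc2)cc1` has not yet been measured in this assay; its change from compound 3 is tert-butyl in place of 2-chloropyridin-4-yl on a saturated chain carbon bound to a nitrogen on an aromatic ring. Among the measured compounds shown here, only the step from compound 1 to compound 2 touches this same position, and it showed that exchanging one aromatic group for another there shifted the number by a modest amount. Replacing that aromatic group with tert-butyl, which has no ring, is a bigger change with no direct precedent among these compounds. Compound 4 is expected to lose some potency, an 8.3-fold higher number from compound 3 to compound 4 (0.92 log units; beyond the scatter). Compound 4 is therefore estimated at 30 nM, with a likely range from 6 nM to 150 nM.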

Compound 4, half-maximal inhibitory concentration: 700 nM
Beside the measured number, compound 4's estimate is 23-fold (1.37 log units) below it, outside the stated range (above it).
By their numbers in this assay, from the lowest: compound 3; then compound 1; then compound 2; then compound 4.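

In this assay, placing tert-butyl on a saturated chain carbon bound to a nitrogen on an aromatic ring, in place of 2-chloropyridin-4-yl, gives a 190-fold higher number from compound 3 to compound 4 (2.29 log units; beyond the scatter), a much larger shift than the exchange of one aromatic group for another, a 9.6-fold higher number from compound 1 to compound 2 (0.98 log units; beyond the scatter). So this position tolerates a change of ring far better than this swap to a group with no ring, and the benzyloxy group shared by compound 3 and compound 4 does not by itself keep the number low. Nothing shown here explains why the number rises so sharply.

Going by these compounds, it remains open whether a cyclohexyl group, a ring that is not aromatic, would behave more like 2-chloropyridin-4-yl or like tert-butyl. A plain phenyl group or a longer straight carbon chain at this position would also help show how much of the ring is needed.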